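A few compounds are considered here, and "the series" means these few. Any claim that something is new, unique, unknown or untested is made for them only; others in the source may bear on it.

Compound 2 `COc1ccc2[nH]c(C(=O)N3CC(=O)N(Cc4ccccc4)[C@@H](Cc4ccccn4)C3)cc2c1` and compound 1 `COc1cccc(CN2C(=O)CN(C(=O)c3cc4cc(OC)ccc4[nH]3)C[C@@H]2Cc2ccccn2)c1` share one core and differ only by hydrogen in place of methoxy on an aromatic carbon. In a physicochemical assay for solubility, read by spectrophotometry, in phosphate buffer, with a stated time of 2 h, at pH 7.4 (a higher number here means a more soluble compound, a lower number a less soluble compound), compound 1 gives 57900 nM. In this assay compound 2 gives only a limit, > 100000 nM, which is the limit of > 100000 nM in this assay, at which 1 of the 2 values shown sits. For the measured compounds named here, the step of an at least 1.7-fold higher number from compound 1 to compound 2 (0.23 log units; that floor lies within the scatter) is the sole measured comparison, and it concerns a different part of the molecule. Compound 3 `COc1ccc2[nH]c(C(=O)N3CC(=O)N(Cc4ccccc4)[C@@H](CN4CCCc5ccccc54)C3)cc2c1` differs from compound 2 by 1,2,3,4-tetrahydroquinolin-1-yl in place of pyridin-2-yl on a saturated chain carbon bound to a saturated ring carbon. Going by the values given here, no measured step bears on that change, so its size is guessed. For compound 3 the expected value is 30000 nM, with a range from 8000 nM to 100000 nM, so the expected step is an at least 3.3-fold lower number from compound 2 to compound 3 (0.52 log units; beyond the scatter).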

Compound 3, solubility: 8500 nM
For compound 3 the middle estimate is 3.5-fold (0.55 log units) above the measured one; the range from low to high includes it.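

Putting 1,2,3,4-tetrahydroquinolin-1-yl in place of pyridin-2-yl on this saturated chain carbon gives an at least 11-fold lower number from compound 2 to compound 3 (1.07 log units; beyond the scatter). So in this assay, a change at this position produces a step clearly beyond the scatter, which the one earlier step, in a different part of the molecule, did not show at its floor. The true size of the step stays unknown, and compound 2 carries only a limit: the limit of > 100000 nM in this assay, at which 1 of the 3 values shown sits.

Going by these compounds, whether a plain phenyl or a morpholin-4-yl at this place would read close to compound 2 or close to compound 3 remains open. Also open, on these data alone, is whether the same change would give a similar step on the core of compound 1.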